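A few compounds are considered here, and "the series" means these few. Any claim that something is new, unique, unknown or untested is made for them only; others in the source may bear on it.

Measured so far in a functional assay on U2OS cells for antagonist activity at proto-oncogene Wnt-3 (Homo sapiens), read by a luciferase reporter, with a stated time of 18 h; a lower number here means that less compound is needed, a higher number that more compound is needed for the effect:
- compound 1 `O=C(CN1CCCC1)N1CCC(NS(=O)(=O)c2cc(S(=O)(=O)c3ccccc3)ccc2C(F)(F)F)CC1`: 190 nM
- compound 2 `CC(C)C(=O)N1CCC[C@H]1C(=O)N1CCC(NS(=O)(=O)c2cc(S(=O)(=O)c3ccccc3)ccc2C(F)(F)F)CC1`: 90 nM
- compound 3 `CN(C)CC(=O)N1CCC[C@H]1C(=O)N1CCC(NS(=O)(=O)c2cc(S(=O)(=O)c3ccccc3)ccc2C(F)(F)F)CC1`: 310 nM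

Compound 3 gives the highest number of the three. Against compound 1 the difference is within the scatter, a 1.6-fold higher number from compound 1 to compound 3 (0.21 log units; within the scatter); against compound 2 it is beyond it, a 3.4-fold higher number from compound 2 to compound 3 (0.54 log units; beyond the scatter). For the measured compounds named here, the one other step, a 2.1-fold lower number from compound 1 to compound 2 (0.32 log units; beyond the scatter), is likewise modest. The whole spread of the series is small.

Compound 4 `CN1CCC[C@H]1C(=O)N1CCC(NS(=O)(=O)c2cc(S(=O)(=O)c3ccccc3)ccc2C(F)(F)F)CC1` is the next point. The change from compound 3 is methyl in place of ((dimethylamino)methyl)carbonyl on an amine nitrogen in a ring, on an amine nitrogen in a ring of the five-membered non-aromatic ring, next to the ring atom that bears a large group. Going by the values given here, no measured step models this cut: every step so far swaps one carbonyl-bearing substituent for another and keeps a carbonyl on that nitrogen, whereas here the carbonyl leaves with the rest of the group. What the steps do show is that changes at this end of the molecule move this assay only modestly in either direction. The expectation for compound 4 is therefore a step of no clear direction, a 1.6-fold lower number from compound 3 to compound 4 (0.19 log units; within the scatter), with a wide range. Estimated value for compound 4: 200 nM, between 60 nM and 700 nM.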

Compound 4, half-maximal effective concentration: 230 nM
The estimate for compound 4 lay 1.2-fold (0.06 log units) below the measured number; low and high end bracket the measured number.
By their numbers in this assay, from the lowest: compound 2; then compounds 1, 4 and 3 (each within the scatter of the next).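

In this assay, the carbonyl on the amine nitrogen in a ring can leave with the rest of the ((dimethylamino)methyl)carbonyl group without a reading beyond the scatter, a 1.3-fold lower number from compound 3 to compound 4 (0.13 log units; within the scatter), so a carbonyl at this position is not required for activity at the level of compound 3. Isopropylcarbonyl is the one group at this nitrogen that separates from methyl, a 2.6-fold higher number from compound 2 to compound 4 (0.41 log units; beyond the scatter), and since compound 3 also carries a carbonyl there, the lower number of compound 2 does not follow from the carbonyl alone. For the compounds shown here, on the carbonyl carbon, 1-methylpyrrolidin-2-yl and (pyrrolidin-1-yl)methyl cannot be told apart, a 1.2-fold higher number from compound 1 to compound 4 (0.08 log units; within the scatter), which leaves compound 2 as the only compound set apart from compound 4.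

The data at hand offer no explanation for any of these differences. Open at this nitrogen are the free secondary amine, with hydrogen in place of methyl, and longer acyl chains such as butyryl or a carboxylic acid-bearing chain, as well as the opposite configuration at the ring atom that bears the large group.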